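A few compounds are considered here, and "the series" means these few. Any claim that something is new, unique, unknown or untested is made for them only; others in the source may bear on it.

Measured in a functional assay on HepG2 cells (Homo sapiens) for antiproliferative activity, read by spectrophotometry, with a stated time of 2 days; a lower number here means a stronger inhibitor of growth, a higher number a weaker inhibitor of growth:
- Compound 1 `CC(=O)N1CCN(c2ccc(Nc3ncc(C(F)(F)F)c(N4Cc5cccc(N(C)S(C)(=O)=O)c5C4)n3)cc2)CC1`: 1400 nM
- Compound 2 `Cc1ccc(Nc2ncc(C(F)(F)F)c(N3Cc4cccc(N(C)S(C)(=O)=O)c4C3)n2)c(Cl)c1`: > 30000 nM (a limit)
- Compound 3 `CN(c1cccc2c1CN(c1nc(Nc3cccc(Oc4ccccc4)c3)ncc1C(F)(F)F)C2)S(C)(=O)=O`: 23000 nM

Only two of these three results are true numbers, and they lie far apart: compound 1 gives 1400 nM, and compound 3 gives 23000 nM. Compound 2 stands at the limit of > 30000 nM in this assay, at which 1 of the 3 values shown sits. Its result is a limit of the assay and not a number, so any comparison starting from compound 2 has no firm value to work from.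

The next compound to be tested is compound 4 `Cc1ccc(Nc2ncc(C(F)(F)F)c(N3Cc4cccc(N(C)S(C)(=O)=O)c4C3)n2)c(C)c1`. It has methyl in place of chloro on an aromatic carbon, ortho to a large group and meta to a methyl group, so 2-chloro-4-methylphenyl becomes 2,4-dimethylphenyl (methyl in place of chloro on an aromatic carbon). Within the data shown here, no measured pair shows the effect of this change in this assay. The expected step of a number no higher from compound 2 to compound 4 (the limit leaves the size open) therefore lies within the scatter, with neither direction favoured, and the assay may again report only a limit.

For compound 4 the estimated value is 30000 nM, with an expected range from 12000 nM to 60000 nM.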

Compound 4, concentration for 50% growth inhibition: 19100 nM
Compound 4: the middle estimate sits 1.6-fold (0.20 log units) above what was measured; the range from low to high includes it.
By their numbers in this assay, from the lowest: compound 1; then compounds 4 and 3 (each within the scatter of the next). At a limit, above all of these: compound 2.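

In this assay, among these compounds, the change from 2-chloro-4-methylphenyl to 2,4-dimethylphenyl gives the first true number for this substitution pattern: compound 4 gives 19100 nM. The swap of chloro for methyl on this aromatic carbon, ortho to a large group, amounts to an at least 1.5-fold lower number from compound 2 to compound 4 (0.19 log units; that floor lies within the scatter). Its real size stays unknown, as compound 2 has only a limit of the assay and no number: the limit of > 30000 nM in this assay, at which 1 of the 4 values shown sits.

The compounds shown leave open whether the true step lies beyond the scatter, and whether the same swap would act alike on another aryl group. They also leave open how an amine or a methoxy group on this same aromatic carbon would read in this assay, and whether such a compound would give a number or again a limit.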